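The source may report more compounds than this note shows. Statements on the series, on what has been measured and on what is new or still open speak of the compounds shown alone.

Working notes on the series, read in a functional assay on UACC-62 cells (Homo sapiens) for cytotoxicity, read by MTT assay, with a stated time of 6 days; on this read-out higher numbers stand for weaker inhibition and lower numbers for stronger inhibition. Compound 1 (`COc1ccccc1NC(=O)SC[C@H](NC(C)=O)C(=O)O`) gives > 200000 nM, which is a limit and not a number. Compound 2 (`CC(=O)N[C@@H](CSC(=O)Nc1cccc(Cl)c1)C(=O)O`) gives > 200000 nM, also a limit. Compound 1 therefore stands on (the limit of > 200000 nM in this assay, at which 2 of the 3 values shown sit), with no number to anchor it. Among the compounds with values here, compound 3 (`CC(=O)N[C@@H](CSC(=O)Nc1ccc(Br)cc1)C(=O)O`) is the only one with a number in this assay, at 320 nM. Within the data shown here, no measured pair differing in one place is available, so no measured step can serve as a guide.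

Compound 4 (`CC(=O)N[C@@H](CSC(=O)Nc1ccccc1)C(=O)O`) departs from compound 1 by one change: hydrogen in place of methoxy on an aromatic carbon. The shared core can reach a measurable potency, as compound 3 shows with 320 nM. Even so, the two limits temper any expectation of a large gain. The expected step is a moderate one toward stronger inhibition, estimated as an at least 4.0-fold lower number from compound 1 to compound 4 (0.60 log units; beyond the scatter), and another limit remains quite possible. For compound 4 the estimated value is 50000 nM, with an expected range of 2000 nM to 200000 nM.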

Compound 4, half-maximal inhibitory concentration: 125000 nM
Beside the measured number, compound 4's estimate is 2.5-fold (0.40 log units) below it; the range from low to high includes it.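

In this assay, compound 4 gives the series a measured reference without a ring substituent, and the first readable step is large: a 390-fold higher number from compound 3 to compound 4 (2.59 log units; beyond the scatter). The potency of compound 3 is therefore not carried by the shared core alone; it goes with bromo on the aromatic carbon. Methoxy and chloro give only floors, set by limits and not by measured sizes, in an at least 1.6-fold lower number from compound 1 to compound 4 (0.20 log units; that floor lies within the scatter) and in an at least 1.6-fold lower number from compound 2 to compound 4 (0.20 log units; that floor lies within the scatter), so among the substituents shown, only bromo goes with a large gain, and the other two compounds remain limits: the limit of > 200000 nM in this assay, at which 2 of the 4 values shown sit.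

On these data alone, it remains open whether an iodo or a methyl group in place of the bromo would hold the number of compound 3. As far as these compounds go, it is also open whether that potency would survive a methyl ester in place of the carboxylic acid.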